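The source may report more compounds than this note shows. Statements on the series, on what has been measured and on what is new or still open speak of the compounds shown alone.

Compound 1 (`C[C@@H]1CN(c2ccc(-c3n[nH]c4cnc(N5CCCCC5)cc34)cn2)CCN1`): 77 nM in an assay on Sf9 cells for inhibition of activin receptor type-1 (Homo sapiens), read by HTRF, with a stated time of 3 h, in the presence of a further agent that is not named here; on this read-out lower numbers stand for stronger inhibition and higher numbers for weaker inhibition. Compound 2 (`CC(C)C(=O)N1C[C@@H](C)N(c2ncc3[nH]nc(-c4ccc(N5CCN[C@H](C)C5)nc4)c3n2)[C@@H](C)C1`): 8 nM. Compound 3 (`C[C@@H]1CN(c2ccc(-c3n[nH]c4cnc(N5[C@H](C)CCC[C@@H]5C)nc34)cn2)CCN1`): 2.5 nM.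

Compound 3 has the lowest number of the three, with compound 2 nearest and compound 1 furthest, both gaps beyond the scatter. Compound 4 (`C[C@@H]1CN(c2ccc(-c3n[nH]c4cnc(N5[C@H](C)COC[C@@H]5C)nc34)cn2)CCN1`) differs from compound 3 in one place: 3,5-dimethylmorpholin-4-yl in place of 2,6-dimethylpiperidin-1-yl on an aromatic carbon. Among the measured compounds shown here, no pair among the measured compounds shows a step of this kind, so there is no measured precedent to lean on. He expects the step of a 2.0-fold higher number from compound 3 to compound 4 (0.30 log units; within the scatter) to be small, towards a slightly higher number, and possibly not beyond the scatter. His estimate for compound 4 in this assay is therefore 5 nM, within a range from 1.5 nM to 16 nM.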

Compound 4, half-maximal inhibitory concentration: 23 nM
Estimate against measurement, compound 4: 4.6-fold (0.66 log units) below; the whole stated range lies below it.
By their numbers in this assay, from the lowest: compound 3; then compound 2; then compound 4; then compound 1.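

In this assay, 3,5-dimethylmorpholin-4-yl in place of 2,6-dimethylpiperidin-1-yl gives a 9.2-fold higher number from compound 3 to compound 4 (0.96 log units; beyond the scatter). The ring size and both methyl groups stay, so exchanging one ring carbon for oxygen at this position is enough to weaken inhibition beyond the scatter. No measurement shown here explains this loss. As far as these compounds go, it remains open whether another ring atom, as in a 4-methyl-2,6-dimethylpiperazin-1-yl group, would be tolerated better than oxygen. From the compounds shown here alone, it also remains open whether an unsubstituted morpholine would behave like its dimethyl counterpart on this core.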